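The compounds below may be only part of what the source reports. "The series", "measured", "known", "first", "only" and "open" are said of these compounds alone.

Measured so far in a physicochemical assay for lipophilicity, read by HPLC, measured as octanol-water partition; on this read-out lower numbers stand for lower lipophilicity and higher numbers for higher lipophilicity:

compound 1, `O=C1O[C@@H](CO)CN1c1ccc(-n2cc(-c3ccccn3)cn2)c(F)c1`: 1.67
compound 2, `CC(=O)OC[C@H]1CN(c2ccc(-n3cc(-c4ccccn4)cn3)c(F)c2)C(=O)O1`: 2.09
compound 3, `COC[C@H]1CN(c2ccc(-n3cc(-c4ccccn4)cn3)c(F)c2)C(=O)O1`: 2.18

Compound 1 carries the lowest of the three numbers. The nearest of the others is compound 2, reached by a number 0.42 log units higher from compound 1 to compound 2 (beyond the scatter), and the furthest is compound 3, reached by a number 0.51 log units higher from compound 1 to compound 3 (beyond the scatter); both steps lie beyond the scatter. Between compound 2 and compound 3 the step is a number 0.09 log units higher from compound 2 to compound 3 (within the scatter), which is within the scatter.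

Compound 4, `O=C1O[C@@H](Cn2ccnn2)CN1c1ccc(-n2cc(-c3ccccn3)cn2)c(F)c1`, has not yet been measured in this assay. Relative to compound 1 its change is 1H-1,2,3-triazol-1-yl in place of hydroxy on a saturated chain carbon bound to a saturated ring carbon.

Both measured steps bear on this change only in part: each replaces the hydrogen on the same oxygen with a small group, and each gives a modest rise. Compound 4 goes further, exchanging the whole hydroxy group for a five-membered aromatic ring with three hetero atoms and no donor. Going by the values given here, no measured pair in this set covers such an exchange, so the direction rests on the two capping steps alone. A modest rise in this assay is therefore expected, of similar size to those seen from compound 1 to compounds 2 and 3, though with wider uncertainty.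

For compound 4 the expected value in this assay is 2.1, estimated to lie between 1.7 and 2.5, corresponding to an expected step of a number 0.43 log units higher from compound 1 to compound 4 (beyond the scatter).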

Compound 4, partition coefficient: 2
The estimate for compound 4 lay 0.10 log units above the measured number; the measured number falls inside the stated range.
By their numbers in this assay, from the lowest: compound 1; then compounds 4, 2 and 3 (each within the scatter of the next).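

In this assay the change at this saturated chain carbon bound to a saturated ring carbon now goes beyond capping the oxygen: 1H-1,2,3-triazol-1-yl in full exchange for hydroxy still gives a modest step beyond the scatter (a number 0.33 log units higher from compound 1 to compound 4 (beyond the scatter)), as capping did. Compound 4 cannot be told apart from the capped compounds, as both steps stay within the scatter (a number 0.18 log units lower from compound 3 to compound 4 (within the scatter); a number 0.09 log units lower from compound 2 to compound 4 (within the scatter)), so methoxy, acetoxy and 1H-1,2,3-triazol-1-yl read alike here despite their different heavy atoms and ring content, and among these four compounds only the free hydroxy of compound 1 stands apart. Nothing at hand explains why such different groups read alike. 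

On these data alone, how an amine, a carboxylic acid or a longer chain in place of hydroxy at this carbon would read in this assay remains open. As far as these compounds go, all four compounds share one core, so whether the same grouping would hold on any other core also remains open.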